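This account rests on a few compounds, and the source may have more. Where it says the series, first, only, none or still open, it means among the compounds named here.

The set comprises compound 1 `Cn1cc(-c2cccc(C(C)(C)O)c2)c2cc(C(=O)NCc3ccc(C(=O)Nc4ccccc4N)cc3)[nH]c2c1=O`, compound 2 `Cn1cc(-c2cc(C(C)(C)O)ccc2OC2CC2)c2cc(C(=O)NCCCCCCC(=O)NO)[nH]c2c1=O`, compound 3 `Cn1cc(-c2ccccc2Oc2ccccc2)c2cc(C(=O)NCCCC(=O)NO)[nH]c2c1=O` and the still unmeasured compound 4 `Cn1cc(-c2ccccc2Oc2ccccc2)c2cc(C(=O)NCCCCCC(=O)NO)[nH]c2c1=O`. In a functional assay on MV4-11 cells (Homo sapiens) for antiproliferative activity, read by CCK-8 assay, with a stated time of 72 h (on this read-out higher numbers stand for weaker inhibition and lower numbers for stronger inhibition), compound 1 gives 2200 nM, compound 2 gives 220 nM and compound 3 gives 380 nM. Compound 3 thus holds the second highest of the three numbers: its gap to compound 2 lies within the scatter, while its gap to compound 1 lies beyond it. Compound 4 differs from compound 3 by 2-(hydroxycarbamoyl)ethyl in place of hydroxycarbamoyl on a saturated chain carbon, three bonds along the chain from an amide-type nitrogen. Within the data shown here, no measured pair shows this change, so the step is judged from the chain-bearing compounds alone. Compound 4 is expected to show a modest gain, a step of a 2.5-fold lower number from compound 3 to compound 4 (0.40 log units; beyond the scatter), with an estimate of 150 nM in the range 60 nM to 400 nM.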

Compound 4, half-maximal inhibitory concentration: 610 nM
Compound 4: the middle estimate sits 4.1-fold (0.61 log units) below what was measured; measured number above the stated range.
By their numbers in this assay, from the lowest: compounds 2, 3 and 4 (each within the scatter of the next, the first and the last beyond it); then compound 1.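

In this assay the change from hydroxycarbamoyl to 2-(hydroxycarbamoyl)ethyl gives a 1.6-fold higher number from compound 3 to compound 4 (0.21 log units; within the scatter) and so brings no difference that can be told from the scatter. Among these compounds, this is the first direct reading of the change on a shared core, and at this position the longer chain neither gains nor loses measurably. Nothing measured here offers an explanation for this result.
On these data alone, whether a still longer chain, such as 3-(hydroxycarbamoyl)propyl, would move the number stays open. So does the effect of a carboxylic acid in place of the hydroxycarbamoyl end.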